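This account rests on a few compounds, and the source may have more. Where it says the series, first, only, none or still open, it means among the compounds named here.

Compound 1 (`C=CC(=O)N[C@@H]1CCCN(S(=O)(=O)c2ccc(NC(=O)OCc3ccccc3)cc2)C1`): > 6 h
Compound 2 (`C=CC(=O)NC1CCN(S(=O)(=O)c2ccc(C(=O)NCc3ccccc3)cc2)CC1`): > 6 h

In an ADME assay on a cell-free system (plasma, Mus musculus) for metabolic stability, tested at 1 uM (on this read-out lower numbers stand for a shorter-lived compound and higher numbers for a longer-lived compound), compound 2 gives > 6 h as its reading, which is a limit of the assay and not a number. Compound 1 gives > 6 h as its reading, and that too is a limit. All that is known so far comes down to one observation (the limit of > 6 h in this assay, at which 2 of the 2 values shown sit).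

Compound 3 (`C=CC(=O)NC1CCN(S(=O)(=O)c2ccc(C(=O)NC3CCCc4ccccc43)cc2)CC1`) has not been measured yet. It differs from compound 2 in one place: 1,2,3,4-tetrahydronaphthalen-1-yl stands in place of benzyl on an amide-type nitrogen (1,2,3,4-tetrahydronaphthalen-1-yl in place of benzyl on an amide-type nitrogen). Among the measured compounds shown here, no two measured compounds differ in a single place, so the data show no step to compare this change with.

For compound 2 the reading of > 6 h is the only anchor for an expectation, and it is a limit. The expected size of the change is a number no higher from compound 2 to compound 3 (the limit leaves the size open) and so nothing beyond the usual scatter. Another reading at the limit is the likeliest outcome. Compound 3 is expected at 6 h with a likely range of 3 h to 12 h on this estimate.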

Compound 3, half-life: > 6 h
Compound 3: a limit, no number; the forecaster's own chance of this, stated with the estimate: 75%; the middle value lies on the limit itself.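

In this assay compound 3 gives > 6 h, which is a limit of the assay and not a number. Compound 2 also reads as a limit, so no step can be read from compound 2 to compound 3. The compounds shown leave open how long each one actually lasts and whether replacing benzyl with 1,2,3,4-tetrahydronaphthalen-1-yl changes that, since all share one result: the limit of > 6 h in this assay, at which 3 of the 3 values shown sit.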